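Fluoro to Hydrogen on the Benzyl Group of Compound 1

The compounds below may be only part of what the source reports. "The series", "measured", "known", "first", "only" and "open" are said of these compounds alone.

compound 1 `CN(Cc1cccc(F)c1)C(=O)CNC(=O)c1ccc(S(C)(=O)=O)c([N+](=O)[O-])c1`: > 60000 nM
compound 2 `CS(=O)(=O)c1ccc(C(=O)NCC(=O)N2CCc3ccccc3C2)cc1[N+](=O)[O-]`: > 60000 nM
compound 3 `CS(=O)(=O)c1ccc(C(=O)NCCC(=O)N2CCc3ccccc32)cc1[N+](=O)[O-]`: > 60000 nM

All three compounds were tested in an assay on isolated protein for inhibition of thyroid hormone receptor alpha (Homo sapiens), read by fluorescence polarization; a lower number here means a stronger inhibitor, a higher number a weaker inhibitor. For compound 1 the value > 60000 nM is a limit of the assay and not a number. Compound 2 and compound 3 likewise give only limits, so every value shown sits at the limit of > 60000 nM in this assay, at which 3 of the 3 values shown sit. Compound 1 therefore cannot be ranked against the other two.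

Compound 4 `CN(Cc1ccccc1)C(=O)CNC(=O)c1ccc(S(C)(=O)=O)c([N+](=O)[O-])c1` differs from compound 1 by hydrogen in place of fluoro on an aromatic carbon. No measured step between two of these compounds exists, and a limit gives no footing for a directed change, so the step that the limit leaves unreadable from compound 1 to compound 4 is expected to be none beyond the scatter. Compound 4 is estimated at 90000 nM, with a range of 30000 nM to 300000 nM, and is expected most likely to be reported again only as a limit.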

Compound 4, half-maximal inhibitory concentration: > 60000 nM
Compound 4 was reported as a limit (the forecaster's own chance of this, stated with the estimate: 90%); the middle value does not contradict the limit.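

Compound 1 and compound 4 each give only a limit of the assay and not a number, so no step can be read between them: the limit of > 60000 nM in this assay, at which 4 of the 4 values shown sit. The compounds shown leave open whether exchanging fluoro for hydrogen changes inhibition at all.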